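Replacing the nitro group of compound 3 with amino

This account rests on a few compounds, and the source may have more. Where it says the series, first, only, none or still open, it means among the compounds named here.

Among the compounds with values here, in a functional assay on cells (Endothelial cell, Bos taurus) for antiproliferative activity (on this read-out higher numbers stand for weaker inhibition and lower numbers for stronger inhibition), compound 3 `COc1ccc(/C(F)=C\c2cc(OC)c(OC)c(OC)c2)cc1[N+](=O)[O-]` gives 329000 nM as the highest of the three numbers measured so far. Compound 1 `COc1ccc(/C(F)=C/c2cc(OC)c(OC)c(OC)c2)cc1N` stands lower at 111000 nM and compound 2 `COc1ccc(/C(F)=C\c2cc(OC)c(OC)c(OC)c2)cc1O` lower again at 4700 nM in the same test.

The next compound to be measured is compound 4 `COc1ccc(/C(F)=C\c2cc(OC)c(OC)c(OC)c2)cc1N` which carries amino in place of nitro on an aromatic carbon with the site ortho to a methoxy group and meta to a large group. Within the data shown here, the one measured step at this site is a 70-fold higher number from compound 2 to compound 3 (1.85 log units; beyond the scatter) for nitro in place of hydroxy on an aromatic carbon. That step was large, and it suggests that the nitro compound may be the poor member of this isomer pair. If amino tracks the hydroxy of compound 2 at 4700 nM rather than nitro, most of that step should be reversed. Compound 1 urges caution: it also carries amino but is the other double-bond isomer of compound 4, and compound 1 still reads 111000 nM in this test, so the upper end stays wide.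

A large fall is therefore expected, with the estimated change being a 66-fold lower number from compound 3 to compound 4 (1.82 log units; beyond the scatter) in this assay and lying beyond the scatter. Compound 4 is expected at 5000 nM within an estimated range of 500 nM to 60000 nM in this assay once tested.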

Compound 4, half-maximal inhibitory concentration: 2100 nM
Estimate against measurement, compound 4: 2.4-fold (0.38 log units) above; the measured number falls inside the stated range.
By their numbers in this assay, from the lowest: compound 4; then compound 2; then compound 1; then compound 3.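

In this assay, amino in place of nitro gives a 160-fold lower number from compound 3 to compound 4 (2.19 log units; beyond the scatter), so the penalty seen earlier, a 70-fold higher number from compound 2 to compound 3 (1.85 log units; beyond the scatter), is not a penalty for any change away from hydroxy at this site, ortho to a methoxy group; among the three groups compared on this double-bond isomer, nitro alone reads far weaker. Amino also goes slightly past hydroxy, with a 2.2-fold lower number from compound 2 to compound 4 (0.35 log units; beyond the scatter), a modest step but one beyond the scatter, which leaves compound 4 with the lowest number of the four compounds. The amino group alone does not set this level, however, as a 53-fold lower number from compound 1 to compound 4 (1.72 log units; beyond the scatter) shows a large step with the group unchanged, and the change can be traced to the double bond alone: the fact that compounds 1 and 4 differ only in the configuration as drawn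

Going by these compounds, whether the double-bond configuration weighs as heavily when hydroxy or nitro occupies this site stays open, since only the amino pair shows that comparison. Also open, on these data alone, is how far the low number of compound 4 extends to other groups here, such as a methylamino group, an acetamide or a carboxylic acid.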